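The source may hold more compounds than are shown below. What is called first, only, known or untested is meant among the compounds shown, and "the series" means these compounds.

Compound 2 `NC(=O)C1CCCN(C(=O)CN2CN(c3ccccc3)C3(CCN(C(=O)c4ccc(C5CCCCC5)cc4)CC3)C2=O)C1` gives 3100 nM in an assay on HEK293 cells for displacement of a labelled ligand from NPC1-like intracellular cholesterol transporter 1 (Homo sapiens) (a lower number here means a stronger inhibitor, a higher number a weaker inhibitor), the higher of the two numbers shown, yet within the scatter of compound 1 `CC(C)(C)OC(=O)NCNC(=O)CN1CN(c2ccccc2)C2(CCN(C(=O)c3ccc(C4CCCCC4)cc3)CC2)C1=O`, which gives 1700 nM. Compound 3 `CS(=O)(=O)NCCCNC(=O)CN1CN(c2ccccc2)C2(CCN(C(=O)c3ccc(C4CCCCC4)cc3)CC2)C1=O` differs from compound 2 by (3-(methanesulfonamido)propyl)amino in place of 3-carbamoylpiperidin-1-yl on a carbonyl carbon. For the measured compounds named here, the one measured step at this same carbonyl carbon, a 1.8-fold higher number from compound 1 to compound 2 (0.26 log units; within the scatter), stayed within the scatter, so a further swap of the group at this position is expected to move this assay little. Compound 3 is therefore estimated at 2500 nM, with a likely range from 1000 nM to 6500 nM, an expected step of a 1.2-fold lower number from compound 2 to compound 3 (0.09 log units; within the scatter).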

Compound 3, half-maximal inhibitory concentration: 3800 nM
For compound 3 the middle estimate is 1.5-fold (0.18 log units) below the measured one; low and high end bracket the measured number.
By their numbers in this assay, from the lowest: compounds 1, 2 and 3 (each within the scatter of the next, the first and the last beyond it).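

In this assay, replacing the 3-carbamoylpiperidin-1-yl ring with the open-chain (3-(methanesulfonamido)propyl)amino gives a 1.2-fold higher number from compound 2 to compound 3 (0.09 log units; within the scatter), so among these groups a ring at this carbonyl carbon is not needed to keep the number at this level. For the compounds shown here, putting 2-(methanesulfonamido)ethyl in place of (tert-butoxycarbonyl)amino gives a 2.2-fold higher number from compound 1 to compound 3 (0.35 log units; beyond the scatter), the only step here beyond the scatter, and a modest one. No measurement available here accounts for either step. As far as these compounds go, whether an amine or a carboxylic acid on this carbonyl carbon would move the number far from these three stays open.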